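A few compounds are considered here, and "the series" means these few. Any claim that something is new, unique, unknown or untested is made for them only; others in the source may bear on it.

Working notes on the series, measured in an assay on isolated protein for binding affinity to histamine H2 receptor (Homo sapiens); on this read-out lower numbers stand for stronger inhibition and higher numbers for weaker inhibition.

Of the compounds shown here, three have numbers so far. Compound 1 `CCCCCC(=O)c1ccc(OCCCN2CCN(C(=O)C(C)(C)O)CC2)cc1` gives 24500 nM in this assay. Compound 2 `CCOC(=O)N1CCN(CCCOc2ccc(C(=O)CC(C)C)cc2)CC1` gives 69200 nM. Compound 3 `C=C(C)C(=O)c1ccc(OCCCN2CCN(C(=O)OCC)CC2)cc1` gives 22400 nM, the lowest of the three numbers; its gap to compound 1 lies within the scatter, so no order between those two is claimed, while the step of a 3.1-fold lower number from compound 2 to compound 3 (0.49 log units; beyond the scatter) is modest but beyond the scatter.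

Compound 4 `CCOC(=O)N1CCN(CCCOc2ccc(C(=O)/C=C/c3ccc(OC)cc3)cc2)CC1` is not yet measured. It differs from compound 3 in one place: 2-(4-methoxyphenyl)ethenyl in place of 1-methylethenyl on a carbonyl carbon. Among the measured compounds shown here, the only measured step that touches the same place is the one from compound 2 to compound 3, where a change on the carbonyl carbon moved the number only modestly, a 3.1-fold lower number from compound 2 to compound 3 (0.49 log units; beyond the scatter). For the measured compounds named here, no measured compound carries an aromatic ring on that carbon, so the effect of the entering 2-(4-methoxyphenyl)ethenyl has no direct precedent.

Given that the one comparable step was modest, the expected step of a 1.5-fold lower number from compound 3 to compound 4 (0.17 log units; within the scatter) in this assay is small and uncertain in direction, most likely within or just beyond the scatter. For compound 4 the estimate is 15000 nM, with a range from 4000 nM to 60000 nM.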

Compound 4, inhibition constant: 6760 nM
Estimate against measurement, compound 4: 2.2-fold (0.35 log units) above; measured number inside the range.
By their numbers in this assay, from the lowest: compound 4; then compounds 3 and 1 (each within the scatter of the next); then compound 2.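

In this assay, the carbonyl carbon now takes a much bulkier group with no loss, as the entry of 2-(4-methoxyphenyl)ethenyl for 1-methylethenyl gives a 3.3-fold lower number from compound 3 to compound 4 (0.52 log units; beyond the scatter) and adds a six-membered aromatic ring of carbon only and a hydrogen-bond acceptor while leaving the count of double bonds outside aromatic rings unchanged. Where the earlier compounds showed only a modest step at this place, the full span from isobutyl to 2-(4-methoxyphenyl)ethenyl is large, with a 10-fold lower number from compound 2 to compound 4 (1.01 log units; beyond the scatter) and with the numbers for the three groups falling in the order isobutyl, 1-methylethenyl, 2-(4-methoxyphenyl)ethenyl. Nothing available explains this drop or ties it to any one feature of the entering group.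

The compounds shown do not separate the aromatic ring from the methoxy group or the double bond, since none carries a plain phenyl group or a saturated 2-(4-methoxyphenyl)ethyl group on this carbon. As far as these compounds go, whether an amine or a carboxylic acid on that ring would move the number further also stays open.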